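The source may hold more compounds than are shown below. What is called first, only, known or untested is meant among the compounds shown, and "the series" means these compounds.

Measured in a functional assay on L1210 cells (Mus musculus) for inhibition; on this read-out higher numbers stand for weaker inhibition and lower numbers for stronger inhibition:
- Compound 1 `COC1=CC(=O)c2ncnc(NCCCN(C)C)c2C1=O`: 1730 nM
- Compound 2 `CN(C)CCCNc1ncnc2c1C(=O)C(N1CCCCC1)=CC2=O`: 1170 nM
- Compound 3 `COC(=O)C(CC(C)C)NC(=O)C(CC(C)C)Nc1ncnc2c1C(=O)C(OC)=CC2=O`: 1300 nM

In this assay, the values of all three compounds lie within the usual scatter of one another, so compound 1 cannot be ranked against the other two. Compound 4 `CCCC(=O)OCCNc1ncnc2c1C(=O)C(OC)=CC2=O` changes the chain of compound 1: (propylcarbonyl)oxy in place of (dimethylamino)methyl on a saturated chain carbon, two bonds along the chain from a nitrogen on an aromatic ring. In words, (propylcarbonyl)oxy stands in place of (dimethylamino)methyl.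

Among the measured compounds shown here, no measured step covers this change. For the measured compounds named here, the only step, a 1.5-fold lower number from compound 1 to compound 2 (0.17 log units; within the scatter), is at a different place and stays within the scatter. Compound 3, at 1300 nM, also sits within the scatter of compound 1. No shift beyond the scatter is therefore expected, though this is weakly supported. The expected change is a 1.2-fold lower number from compound 1 to compound 4 (0.06 log units; within the scatter). For compound 4, the estimate is 1500 nM, with an expected range of 500 nM to 4500 nM.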

Compound 4, half-maximal inhibitory concentration: 2660 nM
For compound 4 the middle estimate is 1.8-fold (0.25 log units) below the measured one; the range from low to high includes it.
By their numbers in this assay, from the lowest: compounds 2, 3, 1 and 4 (each within the scatter of the next, the first and the last beyond it).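

In this assay, replacing (dimethylamino)methyl with (propylcarbonyl)oxy at this chain position gives a 1.5-fold higher number from compound 1 to compound 4 (0.19 log units; within the scatter). The chain can therefore lose its dimethylamino nitrogen and take a larger group with two oxygens, and the number still stays within the scatter of compound 1. No measurement shown here accounts for this result. The compounds shown leave open whether a carboxylic acid or a primary amine at the chain end, or a longer chain, would move the number beyond the scatter.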